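Bromo for fluoro on the aniline ring: clearance expected

This account rests on a few compounds, and the source may have more. Where it says the series, first, only, none or still open, it means among the compounds named here.

The series shares one core, carried in compound 1 `O=C(NCC1CCOCC1)c1cnc(Nc2cccc(F)c2)cc1C1CC1`, compound 2 `CC(C)(C)c1cc(Nc2ccc(Cl)cc2Cl)ncc1C(=O)NCC1CCOCC1` and compound 3 `COc1cccc(Nc2cc(C3CC3)c(C(=O)NCC3CCOCC3)cn2)c1`. Only one of them has a number in an in vitro ADME assay on microsomes from liver (Rattus norvegicus) for metabolic stability; a higher number here means faster removal of the compound, a lower number slower removal: compound 2 gives 2.3 mL.min-1.g-1. In this assay, within the data shown here, compound 1 gives "not determined" (no result reported), and compound 3 gives "not determined" (no result reported), so compound 1 stands without a number of its own, and there is no single step between measured compounds to lean on.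

The step under consideration leads from compound 1 to compound 4 `O=C(NCC1CCOCC1)c1cnc(Nc2cccc(Br)c2)cc1C1CC1`. The change is bromo in place of fluoro on an aromatic carbon of a six-membered aromatic ring of carbon only.

With compound 1 unmeasured, the expectation for this assay rests on compound 2 alone. He expects the step from compound 1 to compound 4 to be small in this assay, at most a modest rise that would stay within the usual scatter, with no direction established by the data shown. Compound 4 is therefore estimated to give 3 mL.min-1.g-1 in this assay, with a range from 1.2 mL.min-1.g-1 to 7.5 mL.min-1.g-1.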

Compound 4, intrinsic clearance in microsomes: 1.6 mL.min-1.g-1
Estimate against measurement, compound 4: 1.9-fold (0.27 log units) above; the measured number falls inside the stated range.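

In this assay, among these compounds, compound 1 gives "not determined" (no result reported) and compound 4 gives 1.6 mL.min-1.g-1 so no step between them can be read. The compounds shown leave open how 3-bromophenyl compares with 3-fluorophenyl on the shared core in this assay and nothing shown bears on the result for compound 4.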